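The compounds below may be only part of what the source reports. "The series", "measured", "known", "first", "only" and "open" are said of these compounds alone.

Of the compounds shown here, two built on the same core have been tested in a functional assay on DLD-1 cells (Homo sapiens) for cytotoxicity, read by MTT assay, with a stated time of 48 h; on this read-out lower numbers stand for stronger inhibition and higher numbers for weaker inhibition. Compound 1 `CC(C)COc1ccc2c(Cl)ccnc2c1` gives 3100 nM in this assay. Compound 2 `C=CCOc1ccc2c(Cl)ccnc2c1` gives 2890 nM in this assay. Compound 2 stands alongside compound 1 rather than apart from it, since a 1.1-fold lower number from compound 1 to compound 2 (0.03 log units; within the scatter), which means the two numbers cannot be told apart.

Compound 3 `CC(C)Oc1ccc2c(Cl)ccnc2c1` differs from compound 2 in one place: isopropyl in place of allyl on an oxygen on an aromatic ring. Within the data shown here, the only measured step that bears on this change, swapping one short chain for another on the same kind of oxygen, was a 1.1-fold lower number from compound 1 to compound 2 (0.03 log units; within the scatter), and nothing among the measured compounds suggests that moving to isopropyl would behave differently. In this assay the step of a 1.0-fold higher number from compound 2 to compound 3 (0.02 log units; within the scatter) is therefore expected, nothing beyond the scatter. Compound 3 is estimated at 3000 nM, with a likely range from 1500 nM to 6000 nM.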

Compound 3, half-maximal inhibitory concentration: 3240 nM
Compound 3: the middle estimate sits 1.1-fold (0.03 log units) below what was measured; measured number inside the range.
By their numbers in this assay, from the lowest: compounds 2, 1 and 3 (each within the scatter of the next).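

In this assay, putting isopropyl in place of allyl on the oxygen takes away the double bond outside aromatic rings, yet the result is a 1.1-fold higher number from compound 2 to compound 3 (0.05 log units; within the scatter), so this double bond makes no measurable difference here. Isopropyl in place of isobutyl gives a 1.0-fold higher number from compound 1 to compound 3 (0.02 log units; within the scatter), which shows that the branched chains can no more be told apart than the allyl and isobutyl pair could, and all three groups on this oxygen now read the same in this assay. No measurement on these compounds speaks to why the three chains read alike.

Going by these compounds, all three groups are small chains of carbon and hydrogen, so it remains open whether an amine, a carboxylic acid or a much longer chain on the same oxygen would move the number beyond the scatter. On these data alone, what a change to the shared core would do also remains open.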